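Hydroxy to amino on two dimethoxybiphenyl cores

This account rests on a few compounds, and the source may have more. Where it says the series, first, only, none or still open, it means among the compounds named here.

Of the compounds shown here, three have been measured in a functional assay on HT-29 cells (Homo sapiens) for cytotoxicity, read by MTT assay, with a stated time of 3 days; on this read-out lower numbers stand for stronger inhibition and higher numbers for weaker inhibition. Compound 1 `COc1ccc(-c2cccc(O)c2)c(OC)c1` gives 54 ug/mL. Compound 2 `COc1ccc(-c2cccc(N)c2)c(OC)c1` gives 49 ug/mL in this assay. Compound 3 `COc1ccc(-c2cccc(O)c2)cc1OC` gives 29 ug/mL in this assay; the values of compound 1 and compound 2 both lie within the scatter of it, so no order among the three is claimed.

Compound 1 and compound 3 carry the same atoms joined differently; the difference between the two cores is not broken down here.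

Among the compounds with values here, the one step that is measured is a 1.1-fold lower number from compound 1 to compound 2 (0.04 log units; within the scatter). The change behind it is amino in place of hydroxy on an aromatic carbon.

Compound 4 `COc1ccc(-c2cccc(N)c2)cc1OC` is not yet measured. It differs from compound 3 by amino in place of hydroxy on an aromatic carbon, the same change as from compound 1 to compound 2, on the core of compound 3 in place of the core of compound 1.

For compound 4 the step expected in this assay is a 1.1-fold lower number from compound 3 to compound 4 (0.03 log units; within the scatter), set beside the measured step from compound 1 to compound 2, because a 1.1-fold lower number from compound 1 to compound 2 (0.04 log units; within the scatter) on the core of compound 1 stayed within the scatter. Within the data shown here, with only one earlier instance of the change and a different core, the expected range is kept wide. For compound 4 the estimate in this assay is 27 ug/mL, between 13 ug/mL and 55 ug/mL.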

Compound 4, half-maximal inhibitory concentration: 4 ug/mL
Compound 4: middle estimate off by 6.8-fold (0.83 log units), on the high side; the whole stated range lies above it.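

In this assay, amino in place of hydroxy on an aromatic carbon gives a 7.3-fold lower number from compound 3 to compound 4 (0.86 log units; beyond the scatter), a step beyond the scatter on the core of compound 3, whereas the same change stayed within the scatter on the core of compound 1. In this series the change therefore does not carry over as a step of fixed size, and the two instances differ by more than two such steps would be expected to scatter: the same change on two cores in this assay, a 1.1-fold lower number (0.04 log units; within the scatter) from compound 1 to compound 2 and a 7.3-fold lower number (0.86 log units; beyond the scatter) from compound 3 to compound 4, 6.6-fold (0.82 log units) apart, beyond the scatter of two such steps. This does not show why the cores respond differently, and with a single pair on each core it does not show which step, if either, is typical of the change, nor whether the gap extends beyond this one read-out on this one cell line.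

The compounds shown leave open whether the step on the core of compound 3 belongs to amino alone or would also appear with another group at the same place, such as a methylamino group, an acetamido group or a carboxylic acid. They also leave open how the change behaves on any further core, so two cores remain the whole basis for any statement about carrying it across the series.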